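Swapping Bromo for Phenyl on a Shared Core

The source may report more compounds than this note shows. Statements on the series, on what has been measured and on what is new or still open speak of the compounds shown alone.

Of the compounds shown here, three built on one shared core have been measured in a functional assay on SR cells (Homo sapiens) for inhibition, read by sulforhodamine B assay, with a stated time of 48 h, tested at 10 uM; on this read-out higher numbers stand for more inhibition of growth at the one concentration tested and lower numbers for less inhibition of growth. Compound 1 `COc1ccc(C(=O)CSc2nccc(Nc3cccc(C(C)=O)c3)n2)cc1` gives 35%. Compound 2 `CC(=O)c1ccc(Nc2ccnc(SCC(=O)c3ccc(Br)cc3)n2)cc1` gives 25%, the lowest of the three numbers; its gap to compound 1 lies within the usual scatter, whereas compound 3 `CCOC(=O)c1ccc(Nc2ccnc(SCC(=O)c3ccc(C#N)cc3)n2)cc1`, which gives 46%, lies beyond it. Compound 4 `CC(=O)c1ccc(Nc2ccnc(SCC(=O)c3ccc(-c4ccccc4)cc3)n2)cc1` differs from compound 2 in a single place: phenyl in place of bromo on an aromatic carbon. For the measured compounds named here, no measured pair shows what this kind of change does here, so the step expected from this swap, a number 5 percentage points higher from compound 2 to compound 4 (within the scatter), is estimated to be small, in neither direction beyond the scatter. Compound 4 is therefore expected to give about 30%, within a range from 10% to 55%.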

Compound 4, percent growth inhibition at one concentration: 41%
Compound 4: middle estimate off by 11 percentage points, on the low side; measured number inside the range.
By their numbers in this assay, from the lowest: compounds 2, 1, 4 and 3 (each within the scatter of the next, the first and the last beyond it).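

In this assay, for the compounds shown here, this is the first comparison on the shared core in which only one place changes. Putting phenyl in place of bromo on this aromatic carbon, para to a large group, gives a number 16 percentage points higher from compound 2 to compound 4 (beyond the scatter). So this position accepts a whole extra six-membered aromatic ring with no loss of growth inhibition, though nothing available explains the rise. On these data alone, whether a smaller amine or a carboxylic acid at this position would shift the number in the same direction remains open. So does whether a second ring of another kind, such as pyridine, would match phenyl.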